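Same Alkyne Swap on a Second Core, Toxicity Expected Unchanged

The source may report more compounds than this note shows. Statements on the series, on what has been measured and on what is new or still open speak of the compounds shown alone.

Three compounds have been measured in an ADME assay on NIH3T3 cells (Mus musculus) for cytotoxicity; on this read-out higher numbers stand for lower toxicity in this test and lower numbers for higher toxicity in this test:
Compound 1, `CCOC(=O)CN(C)CC#Cc1cc2ncnc(Nc3ccc(OCc4cccc(F)c4)c(Cl)c3)c2s1`, gives 52 uM.
Compound 2, `Fc1cccc(COc2ccc(Nc3ncnc4cc(C#CC5CCCC5)sc34)cc2Cl)c1`, gives > 100 uM, which is a limit of the assay and not a number.
Compound 3, `CCOC(=O)CN(C)CC#Cc1ccc2ncnc(Nc3ccc(OCc4cccc(F)c4)c(Cl)c3)c2c1`, gives > 50 uM, again a limit rather than a number.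

The change cyclopentyl in place of (((ethoxycarbonyl)methyl)(methyl)amino)methyl on a triple-bonded carbon produced an at least 1.9-fold higher number from compound 1 to compound 2 (0.28 log units; that floor lies within the scatter). Compound 1 and compound 3 share the side parts but differ in their cores, and that difference is not broken down here. Compound 4, `Fc1cccc(COc2ccc(Nc3ncnc4ccc(C#CC5CCCC5)cc34)cc2Cl)c1`, arises from compound 3 by the same change, (cyclopentyl in place of (((ethoxycarbonyl)methyl)(methyl)amino)methyl on a triple-bonded carbon), at an identical place. Because compound 3 already sits at the limit of > 50 uM in this assay, at which 1 of the 3 values shown sits, and because the earlier step was an at least 1.9-fold higher number from compound 1 to compound 2 (0.28 log units; that floor lies within the scatter), compound 4 is expected to show a step that the limit leaves unreadable from compound 3 to compound 4, within the scatter. Compound 4 is therefore estimated at 100 uM, between 50 uM and 200 uM.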

Compound 4, half-maximal toxic concentration: > 50 uM
Compound 4: a limit, no number; the forecaster's own chance of this, stated with the estimate: 70%; the middle value lies beyond the limit too.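

Going by these compounds alone, compound 3 and compound 4 both end at a limit of the assay rather than a number, so no step between them can be read. The compounds shown leave open where their actual values lie in this assay, and whether cyclopentyl alters the result on this core.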